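Changing the Ring on the Carbon Double-Bonded to Nitrogen

The source may hold more compounds than are shown below. What is called first, only, known or untested is meant among the compounds shown, and "the series" means these compounds.

Measured so far:
Compound 1 `CN(C)CCn1cnnc1-c1cc(Oc2ccc(NC(=O)N/N=C/c3ccc(F)cc3Cl)cc2F)ccn1` gives 870 nM in a functional assay on MKN-45 cells (Homo sapiens) for cytotoxicity, read by MTT assay, with a stated time of 72 h; on this read-out higher numbers stand for weaker inhibition and lower numbers for stronger inhibition.
Compound 2 `CN(C)CCn1cnnc1-c1cc(Oc2ccc(NC(=O)N/N=C/c3ccc(O)c(O)c3)cc2F)ccn1` gives 3240 nM.
Compound 3 `CN(C)CCn1cnnc1-c1cc(Oc2ccc(NC(=O)N/N=C/c3cc(Br)c(O)c(Br)c3)cc2F)ccn1` gives 4320 nM.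

All three share the same core and differ only in the ring attached to the carbon with a double bond to nitrogen. Compound 3 has the highest number of the three; it is close to compound 2, within the scatter, while a 5.0-fold higher number from compound 1 to compound 3 (0.70 log units; beyond the scatter) and a 3.7-fold higher number from compound 1 to compound 2 (0.57 log units; beyond the scatter) both fall beyond it, so compound 1 stands apart as the lowest.

Compound 4 `CN(C)CCn1cnnc1-c1cc(Oc2ccc(NC(=O)N/N=C/c3ccc(F)cc3)cc2F)ccn1` is not yet measured. It differs from compound 3 by 4-fluorophenyl in place of 3,5-dibromo-4-hydroxyphenyl on a carbon with a double bond to nitrogen. The new ring is closer to the ring of compound 1 than to those of compounds 2 and 3: a single halogen on the ring and no hydroxyl. The step most relevant is therefore a 5.0-fold higher number from compound 1 to compound 3 (0.70 log units; beyond the scatter), which run backwards suggests that moving from compound 3 to compound 4 should bring the number down by a modest amount, clearly beyond the scatter. Compound 4 is expected to land near compound 1, at an estimated 1200 nM (range 500 nM to 3000 nM), which means an expected step of a 3.6-fold lower number from compound 3 to compound 4 (0.56 log units; beyond the scatter).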

Compound 4, half-maximal inhibitory concentration: 1030 nM
The estimate for compound 4 lay 1.2-fold (0.07 log units) above the measured number; low and high end bracket the measured number.
By their numbers in this assay, from the lowest: compounds 1 and 4 (each within the scatter of the next); then compounds 2 and 3 (each within the scatter of the next).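

In this assay, 4-fluorophenyl, a ring with no hydroxyl group, gives a 4.2-fold lower number from compound 3 to compound 4 (0.62 log units; beyond the scatter) and a 3.1-fold lower number from compound 2 to compound 4 (0.50 log units; beyond the scatter), so at this carbon with a double bond to nitrogen, both hydroxyl-free rings (compounds 1 and 4) now have lower numbers than both hydroxyl-bearing rings (compounds 2 and 3), and none of the four goes against this pattern. The new compound also isolates the chloro group of compound 1: hydrogen in its place gives a 1.2-fold higher number from compound 1 to compound 4 (0.07 log units; within the scatter), which is within the scatter, so this read-out shows no effect of that chloro group. Nothing available explains why these rings differ as they do.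

Compound 3 carries its bromine atoms together with a hydroxyl group, so the compounds shown leave open what a phenyl ring bearing bromine alone would give. Also open, going by these compounds, is whether an unsubstituted phenyl ring, or one bearing a methoxy group or an amine, would fall with compounds 1 and 4 or with compounds 2 and 3.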